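The source may hold more compounds than are shown below. What is called first, only, known or untested is meant among the compounds shown, and "the series" means these compounds.

The measured compounds:

Compound 1 `CC(=O)c1cc2ccc(OCCCn3cc(CNC(=O)CCCCC4CCSS4)nn3)cc2oc1=O` gives 39.8% in a functional assay on PC-12 cells (Rattus norvegicus) for cytotoxicity, read by MTT assay, with stated times of 3 h and 2 h, tested at 20 uM; on this read-out lower numbers stand for a weaker effect and higher numbers for a stronger effect at the one concentration tested.
Compound 2 `O=C(CCCCC1CCSS1)NCc1cn(CCCOc2ccc3cc(C(=O)O)c(=O)oc3c2)nn1` gives 66.8% in this assay.
Compound 3 `O=C(CCCCC1CCSS1)NCc1cn(CCCOc2ccc3cc(-c4ccc(Br)cc4)c(=O)oc3c2)nn1` gives 69.1% in this assay.

Compound 1 stands lowest of the three numbers. Its nearest neighbour is compound 2, reached by a number 27 percentage points higher from compound 1 to compound 2 (beyond the scatter), and the furthest is compound 3, reached by a number 29.3 percentage points higher from compound 1 to compound 3 (beyond the scatter); both steps lie beyond the scatter. Between compound 2 and compound 3 the step is a number 2.3 percentage points higher from compound 2 to compound 3 (within the scatter), within the scatter.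

Compound 4 `O=C(CCCCC1CCSS1)NCc1cn(CCCOc2ccc3cc(-c4ccc(Cl)c(Cl)c4)c(=O)oc3c2)nn1` has not yet been measured. Compared with compound 1 the change is 3,4-dichlorophenyl in place of acetyl on an aromatic carbon. Among the compounds with values here, the step that bears most directly on it is the one from compound 1 to compound 3, where a bromine-carrying phenyl ring took the place of the acetyl group at the same position and the number rose by a modest amount beyond the scatter. The step from compound 1 to compound 2 shows that exchanging the acetyl group for a different small group also raised the number by a similar amount, so the two measured replacements at this position both point upward.

For compound 4 a step like a number 28.2 percentage points higher from compound 1 to compound 4 (beyond the scatter) is therefore expected, upward and beyond the scatter. Compound 4 is estimated to give 68% in this assay, with a range from 55% to 80%.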

Compound 4, a percentage reported as activity, at one concentration (the size of the read-out at that concentration, not a potency): 51.2%
Beside the measured number, compound 4's estimate is 16.8 percentage points above it; measured number below the stated range.
By their numbers in this assay, from the lowest: compound 1; then compound 4; then compounds 2 and 3 (each within the scatter of the next).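

Replacing the acetyl group with 3,4-dichlorophenyl on this aromatic carbon in this assay still gives a rise, with a number 11.4 percentage points higher from compound 1 to compound 4 (beyond the scatter), so all three replacements shown for the acetyl group point upward, though not by the same amount. A phenyl ring at this place therefore does not settle the number by itself: what the ring carries also counts, as the two halogen-bearing rings differ, with a number 17.9 percentage points lower from compound 3 to compound 4 (beyond the scatter). The carboxy group also separates from the new ring, with a number 15.6 percentage points lower from compound 2 to compound 4 (beyond the scatter), which shows that the similar numbers of compound 2 and compound 3 do not extend to every replacement at this position, and nothing measured here explains these differences.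

The compounds shown leave open whether the lower number of compound 4 goes with the chlorine at the 3-position, with having two halogens, or with chlorine in place of bromine. A plain phenyl ring and a 4-chlorophenyl ring would help separate these possibilities, while an amine on the phenyl ring would test a group of a different kind at this place.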